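The source may hold more compounds than are shown below. What is called first, only, known or untested is meant among the compounds shown, and "the series" means these compounds.

Measured so far in a functional assay on CCRF-CEM cells (Homo sapiens) for cytotoxicity, with a stated time of 72 h; on this read-out lower numbers stand for stronger inhibition and higher numbers for weaker inhibition:
compound 1 `COc1cc(/C=C2\CCC/C(=C\c3ccccc3[N+](=O)[O-])C2=O)cc(OC)c1OC` gives 402 nM;
compound 2 `COc1ccc(/C=C2\CCC/C(=C\c3ccccc3[N+](=O)[O-])C2=O)cc1` gives 7450 nM;
compound 3 `O=C1/C(=C/c2ccc(F)cc2)CCC/C1=C\c1ccccc1[N+](=O)[O-]` gives 1510 nM.

Compound 3 stands second highest of the three numbers: compound 1 lies well below it and compound 2 well above it, both gaps beyond the scatter. The step under consideration leads to compound 4 `O=C1/C(=C/c2ccc(Cl)cc2)CCC/C1=C\c1ccccc1[N+](=O)[O-]`, and the change is chloro in place of fluoro on an aromatic carbon.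

For the measured compounds named here, only one measured step touches the same aromatic carbon: a 4.9-fold lower number from compound 2 to compound 3 (0.69 log units; beyond the scatter). That step exchanged a methoxy for a fluoro, not a fluoro for a chloro, so it does not show what a chloro does at this place, and the series holds no other exchange of one halogen for another. The expectation therefore rests on compound 3 alone, with no direction supported by a measured step, and a step within the scatter is expected: a 1.3-fold lower number from compound 3 to compound 4 (0.10 log units; within the scatter). For compound 4 the estimate in this assay is 1200 nM, with a range from 450 nM to 3500 nM.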

Compound 4, half-maximal inhibitory concentration in the CCRF-CEM assay: 1750 nM
Estimate against measurement, compound 4: 1.5-fold (0.16 log units) below; low and high end bracket the measured number.
By their numbers in the CCRF-CEM assay, from the lowest: compound 1; then compounds 3 and 4 (each within the scatter of the next); then compound 2.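

In the CCRF-CEM assay the exchange of halogens at this place reads as a 1.2-fold higher number from compound 3 to compound 4 (0.06 log units; within the scatter) and so does not separate chloro from fluoro on this aromatic carbon, a comparison that a series with only one halogen could not offer. In the CCRF-CEM assay the step away from methoxy reads as a 4.3-fold lower number from compound 2 to compound 4 (0.63 log units; beyond the scatter) and lies beyond the scatter as it does for fluoro, so the lower number relative to compound 2 holds for both halogens. In a physicochemical assay for lipophilicity (a lower number here means a more polar compound, a higher number a more lipophilic compound), compound 3 gives 4.86 and compound 4 gives 4.86 so the two halogens are not separated on that read-out either.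

No measurement at hand gives a reason for the steps at this place. On these data alone, whether an amine or a carboxylic acid on this aromatic carbon would bring a number in the CCRF-CEM assay outside the scatter of the halogen compounds stays open.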